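Amide aryl variation on a shared chlorinated core

This account rests on a few compounds, and the source may have more. Where it says the series, first, only, none or still open, it means among the compounds named here.

compound 1 `Cc1nc(C(=O)Nc2ccc(Cl)c(-c3nnc4c(Cl)cccn34)c2)cs1`: > 100000 nM
compound 2 `O=C(Nc1ccc(Cl)c(-c2nnc3c(Cl)cccn23)c1)c1ccon1`: 42700 nM

For the measured compounds named here, in a functional assay on A549 cells (Homo sapiens) for antiproliferative activity, read by MTT assay, with a stated time of 72 h (a lower number here means a stronger inhibitor, a higher number a weaker inhibitor), compound 2 gives 42700 nM, the only true number so far. For compound 1 the value > 100000 nM is a limit of the assay, not a number (the limit of > 100000 nM in this assay, at which 1 of the 2 values shown sits). Going by the values given here, the one measured change at the carbonyl carbon is an at least 2.3-fold lower number from compound 1 to compound 2 (0.36 log units; beyond the scatter). Compound 3 `O=C(Nc1ccc(Cl)c(-c2nnc3c(Cl)cccn23)c1)c1c(F)cccc1Cl` differs from compound 2 by 2-chloro-6-fluorophenyl in place of 1,2-oxazol-3-yl on a carbonyl carbon. Among the compounds with values here, only that single step bears on it, and it was at least modest, so a modest improvement is expected here as well; the expected step is a 2.8-fold lower number from compound 2 to compound 3 (0.45 log units; beyond the scatter). For compound 3 a value of 15000 nM is estimated, within 3000 nM to 70000 nM.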

Compound 3, half-maximal inhibitory concentration: 72300 nM
Estimate against measurement, compound 3: 4.8-fold (0.68 log units) below; measured number above the stated range.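

In this assay, 2-chloro-6-fluorophenyl on the carbonyl carbon gives a 1.7-fold higher number from compound 2 to compound 3 (0.23 log units; within the scatter), so a six-momembered carbon ring and 1,2-oxazol-3-yl cannot be told apart at this position. The comparison with the thiazole compound gives an at least 1.3-fold lower number from compound 1 to compound 3 (0.14 log units; that floor lies within the scatter), so no separation is shown there. Compound 1 rests on a limit of the assay, not a number.

Open, going by these compounds, is what an amine or a carboxylic acid on the ring at this carbonyl carbon would do. Also open, on these data alone, is whether any change here reads the same on a different core.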